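Methoxy for Methyl on a Sulfonamide Thiadiazole Pair

The source may report more compounds than this note shows. Statements on the series, on what has been measured and on what is new or still open speak of the compounds shown alone.

Compound 2 `Cc1ccc(S(=O)(=O)Nc2nnc(SCc3ccccc3)s2)cc1` carries a 4-methylphenyl group on its sulfonamide. In a functional assay on MCF7 cells (Homo sapiens) for cytotoxicity, tested at 125 uM (on this read-out higher numbers stand for a weaker effect at the one concentration tested and lower numbers for a stronger effect), compound 2 gives 79%. For the measured compounds named here, the only other measured compound is compound 1 `O=S(=O)(Nc1nnc(SCc2ccccc2)s1)c1ccccc1`, which bears hydrogen where compound 2 bears the methyl; in this assay compound 1 gives 80%. Going by the values given here, the two values stand within the usual scatter of each other, and the one measured step, a number 1 percentage points lower from compound 1 to compound 2 (within the scatter), shows no effect beyond the scatter. Compound 3 `COc1ccc(S(=O)(=O)Nc2nnc(SCc3ccccc3)s2)cc1` differs from compound 2 only in methoxy in place of methyl on an aromatic carbon. Among the compounds with values here, no measured step swaps methyl for methoxy, so the single step known bears on it only loosely: adding a methyl changed nothing beyond the scatter. The expectation is therefore that compound 3 changes little, with a step of no change at the digits printed from compound 2 to compound 3 (within the scatter) expected. Compound 3 is estimated at 79% in this assay, within a range from 66% to 90%.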

Compound 3, a percentage reported as activity, at one concentration (the size of the read-out at that concentration, not a potency): 76%
The estimate for compound 3 lay 3 percentage points above the measured number, within the range that was stated.
By their numbers in this assay, from the lowest: compounds 3, 2 and 1 (each within the scatter of the next).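

With methoxy on the aromatic carbon para to a large group, this assay gives a number 3 percentage points lower from compound 2 to compound 3 (within the scatter), and measured against the unsubstituted parent it gives a number 4 percentage points lower from compound 1 to compound 3 (within the scatter). The earlier pair covered only hydrogen and methyl, whereas this result adds a group with one more heavy atom, an oxygen that counts as a hydrogen-bond acceptor, and hydrogen, methyl and methoxy at this position still cannot be told apart on this read-out. No available measurement speaks to the reason for this.

The compounds shown leave open whether an amine, a carboxylic acid or a longer chain such as butoxy at this position would give a step beyond the scatter. They also leave open whether a change elsewhere on the shared core would do so.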